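The compounds below may be only part of what the source reports. "The series", "measured", "known", "first", "only" and "open" are said of these compounds alone.

In a functional assay on MCF7 cells (Homo sapiens), read by MTT assay, with a stated time of 48 h; a lower number here means a stronger inhibitor, a higher number a weaker inhibitor:
- Compound 1 `CCN(CC)CCNC(=O)c1ccc(C(CC)(CC)c2ccc(OCC(O)C(C)(C)C)c(C)c2)n1CC`: 690 nM
- Compound 2 `CCn1c(C(=O)NCCCN(C)C)ccc1C(CC)(CC)c1ccc(OCC(O)C(C)(C)C)c(C)c1`: 490 nM
- Compound 3 `CCn1c(C(=O)N(C)CCC#N)ccc1C(CC)(CC)c1ccc(OCC(O)C(C)(C)C)c(C)c1`: > 50000 nM (a limit, not a number)

For compound 3 there is thus only (the limit of > 50000 nM in this assay, at which 1 of the 3 values shown sits). Compound 4 `CC[C@@H](C)[C@H](NC(=O)c1ccc(C(CC)(CC)c2ccc(OCC(O)C(C)(C)C)c(C)c2)n1CC)C(=O)O` carries (1-carboxy-2-methylbutyl)amino in place of (2-cyanoethyl)(methyl)amino on a carbonyl carbon. The measured steps that bear on this change are both large: an at least 72-fold higher number from compound 1 to compound 3 (1.86 log units; beyond the scatter), and an at least 100-fold higher number from compound 2 to compound 3 (2.00 log units; beyond the scatter). By contrast, a 1.4-fold lower number from compound 1 to compound 2 (0.15 log units; within the scatter). Compound 4, like compound 3, has neither the (2-(diethylamino)ethyl)amino nor the (3-(dimethylamino)propyl)amino group, so it is expected to remain much closer to compound 3 in this assay. The expected change is modest and towards a lower number: an at least 3.3-fold lower number from compound 3 to compound 4 (0.52 log units; beyond the scatter). For compound 4 the estimate is 15000 nM, with an expected range of 2000 nM to 60000 nM.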

Compound 4, half-maximal inhibitory concentration: 2000 nM
Estimate against measurement, compound 4: 7.5-fold (0.88 log units) above; the range from low to high includes it.
By their numbers in this assay, from the lowest: compounds 2 and 1 (each within the scatter of the next); then compound 4. At a limit, above all of these: compound 3.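

In this assay, a chain without a diethylamino or dimethylamino group need not fall to the limit on this carbonyl carbon: the (1-carboxy-2-methylbutyl)amino group gives an at least 25-fold lower number from compound 3 to compound 4 (1.39 log units; beyond the scatter), a step that starts from a limit and not from a number: the limit of > 50000 nM in this assay, at which 1 of the 4 values shown sits. The amine-bearing chains stay ahead only modestly, with a 4.1-fold higher number from compound 2 to compound 4 (0.61 log units; beyond the scatter) and a 2.9-fold higher number from compound 1 to compound 4 (0.46 log units; beyond the scatter), so an amine on this chain is not required for a value far from that limit.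

Open, on these data alone, is whether this gain follows the carboxylic acid or the amide hydrogen, which compound 4 has and compound 3 lacks. A methyl ester of compound 4, or a 2-cyanoethylamino amide, would separate the two.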